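The source may report more compounds than this note shows. Statements on the series, on what has been measured and on what is new or still open speak of the compounds shown alone.

In a functional assay on A549 cells (Homo sapiens) for cytotoxicity (on this read-out higher numbers stand for an effect only at larger amounts of compound and lower numbers for an effect already at smaller amounts), only one of the three measured relatives gives a true number: compound 1 `COC(=O)[C@H](O)C/C(C)=C\CC[C@H](C)/C=C/C=C(\C)CCCC1=CC(=O)O[C@H]1O` gives 19.4 ug/mL in this test. Compound 2 `COC1C=C(CCC/C(C)=C/C=C/[C@@H](C)CC/C=C(/C)C[C@H]2OC(=O)C(C)=C2O)C(=O)O1` gives only a limit of the assay, > 30 ug/mL as its reading. Compound 3 `CC1=C(O)[C@@H](C/C(C)=C\CC[C@H](C)/C=C/C=C(\C)CCCC2=CCN(CC(=O)O)C2=O)OC1=O` also gives only a limit, > 30 ug/mL as its reading. Its place on the numbers is the limit of > 30 ug/mL in this assay, at which 2 of the 3 values shown sit, and no exact value exists for it.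

Compound 4 `CC1=C(O)[C@@H](C/C(C)=C\CC[C@H](C)/C=C/C=C(\C)CCCC2=CC(=O)N(CC(=O)O)C2)OC1=O` has the same atoms as compound 3, joined differently. The change is a group of 10 heavy atoms (6 carbon, 1 nitrogen, 3 oxygen; one five-membered non-aromatic ring with 1 hetero atom) in place of a group of 10 heavy atoms (6 carbon, 1 nitrogen, 3 oxygen; one five-membered non-aromatic ring with 1 hetero atom), on a saturated chain carbon, three bonds along the chain from a double-bonded chain carbon and it lies on a saturated chain carbon, three bonds along the chain from a double-bonded chain carbon.

Going by the values given here, only one measured step touches this place, a step that the two limits leave unreadable from compound 2 to compound 3 and it offers no size to carry over. No shift beyond the scatter is therefore expected in this assay in either direction. The expected step is a step that the limit leaves unreadable from compound 3 to compound 4 and this is only an estimate. Compound 4 is estimated at 35 ug/mL with an expected range from 18 ug/mL to 70 ug/mL and another limit reading is quite likely.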

Compound 4, concentration for half-maximal effect: > 30 ug/mL
Compound 4 gave a limit, no number (the forecaster's own chance of this, stated with the estimate: 65%); the middle value does not contradict the limit.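

Going by these compounds alone, compound 4 gives only a limit in this assay, so no step among compound 2, compound 3 and compound 4 can be read, and all three share one reading: the limit of > 30 ug/mL in this assay, at which 3 of the 4 values shown sit. On these data alone, whether the different joining of atoms in compound 3 and compound 4 changes the reading in this assay at all stays open.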